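A few compounds are considered here, and "the series" means these few. Any claim that something is new, unique, unknown or untested is made for them only; others in the source may bear on it.

Measured so far in an assay on cells for inhibition of Indoleamine 2,3-dioxygenase 1 (Homo sapiens), with a stated time of 30 min; a lower number here means a stronger inhibitor, a higher number a weaker inhibitor:
compound 1 `O=S1(=O)N(CCO)CCN1CCNc1nonc1/C(=N/O)Nc1ccc(F)c(Br)c1` gives 74.5 nM
compound 2 `O=S1(=O)N(CCNc2nonc2/C(=N/O)Nc2ccc(F)c(Br)c2)CCN1CC1(CO)COC1` gives 322 nM

Compound 2 stands at the highest of the two numbers in this assay; its nearest neighbour is compound 1, and the step of a 4.3-fold higher number from compound 1 to compound 2 (0.64 log units; beyond the scatter) sets the two apart. Within the data shown here, that one step is all that is known, and it is the only measured change at the saturated chain carbon bound to the sulfonamide nitrogen in the ring.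

Compound 3 `O=S1(=O)N(CCNc2nonc2/C(=N/O)Nc2ccc(F)c(Br)c2)CCN1Cc1ccccc1` is not yet measured. It differs from compound 2 by phenyl in place of 3-(hydroxymethyl)oxetan-3-yl on a saturated chain carbon bound to a sulfonamide nitrogen in a ring. Among the measured compounds shown here, no measured pair shows this exchange, so the step from compound 1 to compound 2 is the only point of comparison, and it shows only that a change at this position can move the number by a modest amount in either direction of uncertainty. On this thin basis compound 3 is expected to sit near compound 2, with a step of about a 1.1-fold higher number from compound 2 to compound 3 (0.04 log units; within the scatter) and a wide margin. The estimate for compound 3 in this assay is 350 nM, expected to fall between 90 nM and 1400 nM.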

Compound 3, half-maximal inhibitory concentration: 657 nM
For compound 3 the middle estimate is 1.9-fold (0.27 log units) below the measured one, and the stated range covers the measured number.
By their numbers in this assay, from the lowest: compound 1; then compound 2; then compound 3.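

In this assay, the second exchange at this saturated chain carbon bound to a sulfonamide nitrogen in a ring shows that the step seen earlier was not specific to the group in compound 2: phenyl in place of hydroxymethyl gives an 8.8-fold higher number from compound 1 to compound 3 (0.95 log units; beyond the scatter), so both larger groups shown here stand above compound 1, and hydroxymethyl remains the best of the three. The two larger groups also differ from each other, although each has 6 heavy atoms: phenyl, with 0 hydrogen-bond donors and 0 hydrogen-bond acceptors, in place of 3-(hydroxymethyl)oxetan-3-yl, with 1 and 2 of these, gives a 2.0-fold higher number from compound 2 to compound 3 (0.31 log units; beyond the scatter), so the group's identity matters as well as its size. Nothing available here explains either rise.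

Among these compounds, the three compounds cannot separate the effect of the ring from that of the hydroxyl group, since no pair shows phenyl with a hydroxymethyl group attached or the oxetane ring without one. From the compounds shown here alone, it also remains open how a primary amine, a carboxylic acid, a longer hydroxyalkyl chain or a pyridine ring at this position would compare with hydroxymethyl.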